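The compounds below may be only part of what the source reports. "The series", "measured", "known", "first", "only" and "open" are said of these compounds alone.

Series measured in a functional assay on HeLa S3 cells (Homo sapiens) for cytotoxicity, read by WST assay; a higher number here means a weaker inhibitor, a lower number a stronger inhibitor:
- compound 1 `CC(C)CC(=O)O[C@@H]1OC=C(CO)[C@H]2C[C@H](OC(=O)/C=C\c3ccc(O)cc3)[C@](O)(CO)[C@@H]12`: 3110 nM
- compound 2 `CCC(C)CC(=O)O[C@@H]1OC=C(CO)[C@H]2C[C@H](OC(=O)/C=C/c3ccc(O)cc3)[C@](O)(CO)[C@@H]12`: 7400 nM

Compound 2, at 7400 nM, holds the higher of the two numbers, so it is the weaker inhibitor of the pair, and its gap to compound 1 lies beyond the usual scatter.

The next compound is compound 3 `CC(C)CC(=O)O[C@@H]1OC=C(CO)[C@H]2C[C@H](OC(=O)/C=C/c3ccc(O)cc3)[C@](O)(CO)[C@@H]12`. The change from compound 2 is hydrogen in place of methyl on a saturated chain carbon, three bonds along the chain from a carbonyl carbon. Cut one bond further out, this reads 2-methylbutyl to isobutyl.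

Within the data shown here, no measured step isolates this change, since compound 1 and compound 2 do not differ in one place only. Compound 1, at 3110 nM, also carries the isobutyl chain and is the only hint, a weak one, towards a lower number. In this assay the change is therefore expected to give a small shift towards a lower number, with no step beyond the scatter. The expected step is a 1.3-fold lower number from compound 2 to compound 3 (0.13 log units; within the scatter). For compound 3 the estimated value is 5500 nM, with an expected range from 2500 nM to 12000 nM.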

Compound 3, half-maximal inhibitory concentration: 2890 nM
Estimate against measurement, compound 3: 1.9-fold (0.28 log units) above, within the range that was stated.
By their numbers in this assay, from the lowest: compounds 3 and 1 (each within the scatter of the next); then compound 2.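

In this assay, among these compounds, the change from the 2-methylbutyl to the isobutyl chain is the first change in a single place that can be read, and it gives a 2.6-fold lower number from compound 2 to compound 3 (0.41 log units; beyond the scatter) as a modest step. This shows that the saturated chain carbon, three bonds along the chain from a carbonyl carbon, is not silent in this read-out: a methyl there goes with the weaker compound of this pair, although this rests on one pair only. The second pair isolates the double bond, where a 1.1-fold lower number from compound 1 to compound 3 (0.03 log units; within the scatter) means that, with the isobutyl chain in place, the Z and E forms cannot be told apart in this assay, and the comparison is a clean one: the fact that compounds 1 and 3 differ only in the configuration as drawn.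

Still open, going by these compounds, is whether the step follows chain length or the methyl branch alone, which a straight pentyl chain, a longer hexyl chain or an amine on the chain would help to separate. Also open, on these data alone, is whether the double bond stays equally without effect when the 2-methylbutyl chain is present, and what a methoxy group in place of the phenol hydroxyl would do.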